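Pyrrolidine versus imidazole on an alkyne-linked carbamate and urea series

A few compounds are considered here, and "the series" means these few. Any claim that something is new, unique, unknown or untested is made for them only; others in the source may bear on it.

Measured so far:
compound 1 `COC(=O)N(C)C(C)C#CCN1CCCC1` — > 100 mg/kg
compound 2 `COC(=O)N(C)C(C)C#CCn1ccnc1` — > 100 mg/kg
compound 3 `CN(C)C(=O)N(C)CC#CCN1CCCC1` — 6.6 mg/kg

In a functional assay on the whole organism for antagonist activity, with Mus musculus as the target (on this read-out higher numbers stand for an effect only at larger amounts of compound and lower numbers for an effect already at smaller amounts), compound 1 reaches only a limit of the assay, > 100 mg/kg, and not a number. In this assay compound 2 likewise reaches only a limit, > 100 mg/kg. Among the measured compounds shown here, compound 3 is the one compound of the three with a number in this assay, 6.6 mg/kg. The change from compound 1 to compound 2 is 1H-imidazol-1-yl in place of pyrrolidin-1-yl on a saturated chain carbon bound to a triple-bonded carbon; the step it made, a step that the two limits leave unreadable from compound 1 to compound 2, cannot be read from two limits, a point underlined by the limit of > 100 mg/kg in this assay, at which 2 of the 3 values shown sit. How the core of compound 3 differs from that of compound 1 is not broken down here.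

Compound 4 `CN(C)C(=O)N(C)CC#CCn1ccnc1` is not yet measured. It differs from compound 3 by 1H-imidazol-1-yl in place of pyrrolidin-1-yl on a saturated chain carbon bound to a triple-bonded carbon, the same change as that from compound 1 to compound 2, made on the same place. For the measured compounds named here, since the earlier step is unreadable, there is no measured size to carry over; the only anchor is compound 3 at 6.6 mg/kg. A step of a 4.5-fold higher number from compound 3 to compound 4 (0.66 log units; beyond the scatter) is expected, a loss that stays short of the limit but is set with wide uncertainty. Compound 4 is estimated at 30 mg/kg, with a range from 6 mg/kg to 150 mg/kg.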

Compound 4, dose for half-maximal effect: 11.8 mg/kg
For compound 4 the middle estimate is 2.5-fold (0.41 log units) above the measured one; the range from low to high includes it.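

In this assay the exchange of pyrrolidin-1-yl for 1H-imidazol-1-yl on a saturated chain carbon bound to a triple-bonded carbon gives a 1.8-fold higher number from compound 3 to compound 4 (0.25 log units; within the scatter), so on this core the two groups are not told apart. The same change on the core of compound 1 leads to compound 2, but that step cannot be read, and it offers no size to set against the readable one: the limit of > 100 mg/kg in this assay, at which 2 of the 4 values shown sit. Transfer of the change between the two cores therefore stays untested, as the single readable instance shows tolerance of the exchange on the core of compound 3 and says nothing about how it behaves on the core of compound 1.

Still open, as far as these compounds go, is whether other groups at this place, such as a piperidine, a dimethylamino group or a carboxylic acid, would also leave the value in this assay within the scatter of compound 3. Also open is which of the differences between the cores of compound 1 and compound 3 matters for this read-out, since the compounds shown include no pair that differs in only one of those features.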